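Swapping an amine substituent for a benzoyl group

The source may report more compounds than this note shows. Statements on the series, on what has been measured and on what is new or still open speak of the compounds shown alone.

Of the compounds shown here, two have been measured in an assay on FRT cells with Cystic fibrosis transmembrane conductance regulator variant F508del (Homo sapiens) as the target, read by fluorescence, with a stated time of 25 min; on this read-out lower numbers stand for smaller maximal responses and higher numbers for larger maximal responses. Compound 1, with the structure `CN(C)CCN1CCN(c2nc(-c3ccncc3)nc3c2CN(Cc2ccccc2)CC3)CC1`, is reported in this assay as "not active" (no number reported), without a number attached. Compound 2, with the structure `CN(C)CCN1CCN(c2nc(-c3ccccn3)nc3c2CN(Cc2ccsc2)CC3)CC1`, reaches 79.8% in this assay. Within the data shown here, compound 2 therefore stands alone as the only compound with a number, and nothing can be said about the size of any step between measured compounds, since compound 1 carries no number.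

Compound 3, with the structure `CN(C)CCN1CCN(c2nc(-c3ccccn3)nc3c2CN(C(=O)c2ccccc2)CC3)CC1`, has not yet been measured. It differs from compound 2 in one place: benzoyl in place of (thiophen-3-yl)methyl on an amine nitrogen in a ring. Among the measured compounds shown here, with only one number in hand, no measured step can guide the expectation, so the estimate rests on the single value of compound 2 and on the size of the change. A drop in maximal response is expected for compound 3, of a size given by a number 19.8 percentage points lower from compound 2 to compound 3 (beyond the scatter), beyond the usual scatter. Compound 3 is accordingly estimated to reach 60% in this assay, within a range from 25% to 95%.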

Compound 3, largest response reached (Emax), in percent of the reference or control that the assay uses: "not active" (no number reported)
For compound 3 the study gives words and no number; no gap can be computed for the estimate.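

In this assay compound 3 is reported as "not active" (no number reported), whereas compound 2 gives 79.8%; with words on one side and a number on the other, no new step can be read from this pair. No measurement shown here bears on this result. The compounds shown leave open how large the difference between compound 2 and compound 3 is and what part of it the benzoyl group accounts for.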